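One Chlorine More: Expected Growth Inhibition of Compound 4

This account rests on a few compounds, and the source may have more. Where it says the series, first, only, none or still open, it means among the compounds named here.

Compound 1 `O=C(NOCc1ccccc1)c1cn(-c2ccccc2)nc1-c1ccccc1` and compound 2 `O=C(NOCc1ccccc1)c1cn(-c2ccccc2)nc1-c1ccc(Cl)cc1` differ by chloro in place of hydrogen on an aromatic carbon. In a functional assay on MCF7 cells (Homo sapiens) for antiproliferative activity, read by MTT assay, with a stated time of 48 h, in the presence of a further agent that is not named here (on this read-out lower numbers stand for stronger inhibition of growth and higher numbers for weaker inhibition of growth), compound 1 gives 13400 nM, while compound 2 gives 10800 nM; the step is a 1.2-fold lower number from compound 1 to compound 2 (0.09 log units; within the scatter). Compound 3 `O=C(NOCc1ccccc1Cl)c1cn(-c2ccccc2)nc1-c1ccc(F)cc1` gives 11400 nM in this assay; how its core differs from the core of compound 1 is not broken down here. Compound 4 `O=C(NOCc1ccc(Cl)cc1Cl)c1cn(-c2ccccc2)nc1-c1ccc(F)cc1` differs from compound 3 by chloro in place of hydrogen on an aromatic carbon. This is the same kind of change as that between compound 1 and compound 2, not the same: in compound 4 the entering chloro sits meta to a chloro group, a feature the earlier place does not have. Because a 1.2-fold lower number from compound 1 to compound 2 (0.09 log units; within the scatter) stayed within the scatter, the expected outcome is a 1.2-fold lower number from compound 3 to compound 4 (0.08 log units; within the scatter). Compound 4 is estimated to give 9500 nM, lying between 4000 nM and 22000 nM.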

Compound 4, concentration for 50% growth inhibition: 25300 nM
Compound 4: the middle estimate sits 2.7-fold (0.43 log units) below what was measured; measured number above the stated range.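

Adding the chloro to the 2-chlorobenzyl group gives a 2.2-fold higher number from compound 3 to compound 4 (0.35 log units; beyond the scatter), so the number rises here, whereas the earlier step stayed within the scatter. The same replacement of hydrogen by chloro thus did not carry over unchanged from one core to the other in this assay: the same change on two cores in this assay, a 1.2-fold lower number (0.09 log units; within the scatter) from compound 1 to compound 2 and a 2.2-fold higher number (0.35 log units; beyond the scatter) from compound 3 to compound 4, 2.8-fold (0.44 log units) apart, beyond the scatter of two such steps. These two steps do not show why, since the entering chloro in compound 4 sits meta to a chloro group and the two steps also differ in the ring that carries the change.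

From the compounds shown here alone, it remains open whether a methyl or methoxy group in the same place would give a similar step. Also open, going by these compounds, is how a chloro would act on the unsubstituted benzyl group of compound 1.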